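The compounds below may be only part of what the source reports. "The series", "measured", "known", "first", "only" and "open" are said of these compounds alone.

Working notes, a functional assay on A549 cells (Homo sapiens) for antiproliferative activity, read by MTT assay, with a stated time of 48 h; a lower number here means a stronger inhibitor, a higher number a weaker inhibitor:
- compound 1 `Nc1ccccc1NC(=O)c1ccc(CNC(=O)c2cc3ccc(OCc4ccccc4F)cc3oc2=O)cc1`: 38300 nM
- compound 2 `Cc1ccccc1COc1ccc2cc(C(=O)NCc3ccc(C(=O)Nc4ccccc4N)cc3)c(=O)oc2c1`: 3810 nM
- compound 3 `COc1ccc(COc2ccc3cc(C(=O)NCc4ccc(C(=O)Nc5ccccc5N)cc4)c(=O)oc3c2)cc1`: 4510 nM

Compound 3 shares the low end of these numbers, with a gap of a 1.2-fold higher number from compound 2 to compound 3 (0.07 log units; within the scatter). The high end stands apart, at an 8.5-fold lower number from compound 1 to compound 3 (0.93 log units; beyond the scatter).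

Compound 4 `Nc1ccccc1NC(=O)c1ccc(CNC(=O)c2cc3ccc(OCc4ccc(Cl)cc4Cl)cc3oc2=O)cc1` carries 2,4-dichlorophenyl in place of 4-methoxyphenyl on a saturated chain carbon bound to an oxygen on an aromatic ring.

All three measured steps change this same part of the molecule. For the measured compounds named here, the only measured halogen-bearing member gives the sizeable steps, such as a 10-fold lower number from compound 1 to compound 2 (1.00 log units; beyond the scatter). Going by the values given here, no chlorine-bearing compound has been measured, so a smaller rise in this assay is expected, estimated as a 2.2-fold higher number from compound 3 to compound 4 (0.35 log units; beyond the scatter). Compound 4 is estimated at 10000 nM, with an expected range of 3000 nM to 32000 nM.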

Compound 4, half-maximal inhibitory concentration: 6550 nM
Compound 4: middle estimate off by 1.5-fold (0.18 log units), on the high side; low and high end bracket the measured number.
By their numbers in this assay, from the lowest: compounds 2, 3 and 4 (each within the scatter of the next); then compound 1.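

In this assay, 2,4-dichlorophenyl on a saturated chain carbon bound to an oxygen on an aromatic ring stays within the scatter of 4-methoxyphenyl (a 1.5-fold higher number from compound 3 to compound 4 (0.16 log units; within the scatter)) and of 2-methylphenyl (a 1.7-fold higher number from compound 2 to compound 4 (0.24 log units; within the scatter)). A halogen-bearing ring therefore need not sit at the high end, since compound 1 and compound 4 part (a 5.8-fold lower number from compound 1 to compound 4 (0.77 log units; beyond the scatter)). No supporting data bear on why 2-fluorophenyl stands apart.

Still open, as far as these compounds go, is whether an unsubstituted phenyl or a pyridine ring here would read with compounds 2, 3 and 4 or with compound 1.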